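The source may report more compounds than this note shows. Statements on the series, on what has been measured and on what is new or still open speak of the compounds shown alone.

Working notes on the series. For the measured compounds named here, compound 1 `N[C@H]1CC[C@H](Nc2c(C(=O)NCc3ccc(F)cc3)nc(Br)c3cccnc23)CC1` is the only member with a number in a functional assay on MCF7 cells (Homo sapiens) for cytotoxicity, read by MTT assay, with a stated time of 72 h; on this read-out higher numbers stand for weaker inhibition and lower numbers for stronger inhibition: compound 1 gives 2000 nM. Going by the values given here, compound 2 `C[C@H](NC(=O)c1nc(Br)c2cccnc2c1N[C@H]1CC[C@H](N)CC1)c1ccc(F)cc1` was run in this assay and gives "not determined" (no result reported), and compound 3 `N[C@H]1CC[C@H](Nc2c(C(=O)NCc3ccc(Cl)cc3)nc(Br)c3cccnc23)CC1` likewise gives "not determined" (no result reported), so compound 1 stands alone and no steps between measured compounds can be stated. Compound 4 `COC(=O)CNc1c(C(=O)NCc2ccc(F)cc2)nc(Br)c2cccnc12` has not yet been measured in this assay. Relative to compound 1 the change is (methoxycarbonyl)methyl in place of 4-aminocyclohexyl on a nitrogen on an aromatic ring, with 4-aminocyclohexyl leaving the nitrogen on the aromatic ring and (methoxycarbonyl)methyl entering at the same place. With only one measured point, the step is expected to fall outside the usual scatter and toward weaker inhibition, estimated as a 3.0-fold higher number from compound 1 to compound 4 (0.48 log units; beyond the scatter). For compound 4 the expected value in this assay is 6000 nM, with a range from 1500 nM to 25000 nM.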

Compound 4, half-maximal inhibitory concentration: > 10000 nM
Compound 4 gave a limit, no number; the forecaster's own chance of this, stated with the estimate: 25%; at least 1.6-fold (0.22 log units) between middle value and limit.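

In this assay compound 4 reads > 10000 nM, which is a limit of the assay and not a number. Even so, (methoxycarbonyl)methyl in place of 4-aminocyclohexyl on a nitrogen on an aromatic ring gives an at least 5.0-fold higher number from compound 1 to compound 4 (0.69 log units; beyond the scatter). For the compounds shown here, this is the first readable step, and it shows that the group on this nitrogen matters in this assay.

The compounds shown leave open which part of the change carries the step: the ring, the amine or the ester. Also open, going by these compounds, is how an open-chain amine or a carboxylic acid on the same nitrogen would read.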